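The source may hold more compounds than are shown below. What is called first, only, known or untested is meant among the compounds shown, and "the series" means these compounds.

Among the compounds with values here, in a functional assay on K562 cells (Homo sapiens) for cytotoxicity, read by sulforhodamine B assay (a lower number here means a stronger inhibitor of growth, a higher number a weaker inhibitor of growth), compound 2 `CC1=CC[C@@H]([C@@](C)(O)CCCC(C)(C)NC(=S)N/N=C\c2cccc([N+](=O)[O-])c2)CC1` gives 560 nM, the lower of the two numbers measured so far, while compound 1 `CC1=CC[C@@H]([C@@](C)(O)CCCC(C)(C)NC(=S)N/N=C\c2ccc(O)cc2)CC1` gives 31100 nM. The next compound, compound 3 `CC1=CC[C@@H]([C@@](C)(O)CCCC(C)(C)NC(=S)N/N=C\c2ccc(Cl)cc2)CC1`, keeps the shared core and differs from compound 2 in one place, on a carbon with a double bond to nitrogen: 4-chlorophenyl in place of 3-nitrophenyl on a carbon with a double bond to nitrogen. In words, 4-chlorophenyl takes the place of 3-nitrophenyl. Within the data shown here, only one measured step bears on this place: a 56-fold lower number from compound 1 to compound 2 (1.74 log units; beyond the scatter), which is large and came with 3-nitrophenyl replacing 4-hydroxyphenyl. That step shows that the number can move widely with the group at this place, but it does not involve 4-chlorophenyl, so it guides the direction only loosely. A moderate move towards a higher number is expected, estimated as a 2.7-fold higher number from compound 2 to compound 3 (0.43 log units; beyond the scatter). For compound 3 the estimate is 1500 nM, with an expected range of 350 nM to 9000 nM.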

Compound 3, concentration for total growth inhibition: 730 nM
Estimate against measurement, compound 3: 2.1-fold (0.31 log units) above; measured number inside the range.
By their numbers in this assay, from the lowest: compounds 2 and 3 (each within the scatter of the next); then compound 1.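

In this assay, 4-chlorophenyl in place of 3-nitrophenyl gives a 1.3-fold higher number from compound 2 to compound 3 (0.12 log units; within the scatter), so these two groups cannot be told apart at this place, although the entering group has 0 hydrogen-bond acceptors and the leaving group has 2. Chloro in place of hydroxy on an aromatic carbon gives a 43-fold lower number from compound 1 to compound 3 (1.63 log units; beyond the scatter), which shows that a large step away from the 4-hydroxyphenyl of compound 1 does not depend on the nitro group. No evidence is available to explain either step.

On these data alone, it remains open whether the high number of compound 1 is specific to the hydroxy group, which 4-methoxyphenyl or 4-aminophenyl could test. Also open, as far as these compounds go, is whether the substituent's location on the ring matters, which 3-chlorophenyl or 4-nitrophenyl could test.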